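Replacing a ring nitrogen with a chlorine on the core

The source may report more compounds than this note shows. Statements on the series, on what has been measured and on what is new or still open speak of the compounds shown alone.

Compound 2 `CC/C(=C(/c1ccc(/C=C/C(=O)O)cc1)c1ccc2[nH]ncc2n1)c1ccccc1`: 33 nM
Compound 1 `COC/C(=C(/c1ccc(/C=C/C(=O)O)cc1)c1ccc2[nH]ncc2c1)c1ccccc1`: 88 nM

For the measured compounds named here, in a functional assay on MCF7 cells (Homo sapiens) for cytotoxicity, read by CellTiter-Glo, with a stated time of 5 days (a higher number here means a weaker inhibitor, a lower number a stronger inhibitor), compound 2 gives 33 nM, the lowest of the two numbers so far; compound 1 gives 88 nM, a higher number beyond the usual scatter. Compound 3 `CC/C(=C(/c1ccc(/C=C/C(=O)O)cc1)c1cc(Cl)c2[nH]ncc2c1)c1ccccc1` differs from compound 2 in one place: a group of 10 heavy atoms (7 carbon, 2 nitrogen, 1 chlorine; one five-membered aromatic ring with 2 hetero atoms, one six-membered aromatic ring of carbon only) in place of a group of 9 heavy atoms (6 carbon, 3 nitrogen; one five-membered aromatic ring with 2 hetero atoms, one six-membered aromatic ring with 1 hetero atom), on a double-bonded chain carbon bound to an aromatic carbon and a double-bonded chain carbon. Going by the values given here, no pair of measured compounds differing in a single place is available to calibrate this change. A small shift toward a weaker inhibitor, a 1.4-fold higher number from compound 2 to compound 3 (0.13 log units; within the scatter), is expected, within or close to the scatter. Compound 3 is therefore estimated at 45 nM, with a range from 15 nM to 150 nM.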

Compound 3, half-maximal inhibitory concentration: 56 nM
Beside the measured number, compound 3's estimate is 1.2-fold (0.09 log units) below it, and the stated range covers the measured number.
By their numbers in this assay, from the lowest: compounds 2, 3 and 1 (each within the scatter of the next, the first and the last beyond it).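

In this assay, placing 7-chloro-1H-indazol-5-yl on the double-bonded chain carbon gives a 1.7-fold higher number from compound 2 to compound 3 (0.23 log units; within the scatter), so compound 3 and compound 2 cannot be told apart. At this place, then, a group with a six-membered aromatic ring of carbon only and a chlorine reads like one with a six-membered aromatic ring holding a nitrogen. Nothing measured here bears on what lies behind this result. The compounds shown leave open how a fluorine, a methyl group or an amine in place of the chlorine would read, and so whether the chlorine contributes at all.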